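Notes on the amide tail of a shared core

The compounds below may be only part of what the source reports. "The series", "measured", "known", "first", "only" and "open" are said of these compounds alone.

Three compounds share one core and differ only at the end of the amide tail. In an assay on HeLa cells for displacement of a labelled ligand from adenosine receptor A3 (Homo sapiens), read by fluorescence polarization, with a stated time of 30 min (a higher number here means a weaker inhibitor, a lower number a stronger inhibitor), compound 1 `COc1ccc(-c2cc(NC(=O)CCC(=O)NCC(=O)NC(C)(C)C)nc(-c3ccc(OC)cc3)n2)cc1` gives 15000 nM. Compound 2 `COc1ccc(-c2cc(NC(=O)CCC(=O)NCC(=O)NC3CCCCC3)nc(-c3ccc(OC)cc3)n2)cc1` gives 35100 nM, and compound 3 `COc1ccc(-c2cc(NC(=O)CCC(=O)NCC(=O)NCc3ccccc3)nc(-c3ccc(OC)cc3)n2)cc1` gives 26900 nM. Compound 3 stands second highest of the three numbers, with compound 2 nearest and compound 1 furthest; the steps of a 1.8-fold higher number from compound 1 to compound 3 (0.25 log units; within the scatter) and a 1.3-fold lower number from compound 2 to compound 3 (0.12 log units; within the scatter) are both within the scatter, and only a 2.3-fold higher number from compound 1 to compound 2 (0.37 log units; beyond the scatter) reaches beyond it.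

Compound 4 `COc1ccc(-c2cc(NC(=O)CCC(=O)N(C)CC(=O)NC3CCCCC3)nc(-c3ccc(OC)cc3)n2)cc1` is the next compound to be measured. The change is ((cyclohexylcarbamoyl)methyl)(methyl)amino in place of ((benzylcarbamoyl)methyl)amino on a carbonyl carbon. Among the compounds with values here, it combines two alterations: the cyclohexyl amide already seen in compound 2, whose value 35100 nM sits close to that of compound 3, and a methyl on an amide-type nitrogen, for which no measured pair exists. The known steps bear on the first part only and are small, so no step beyond the scatter is expected in this assay; the estimated step is a 1.5-fold higher number from compound 3 to compound 4 (0.17 log units; within the scatter). For compound 4 the expected value is 40000 nM, with a range of 15000 nM to 110000 nM.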

Compound 4, inhibition constant: 18500 nM
Beside the measured number, compound 4's estimate is 2.2-fold (0.33 log units) above it; low and high end bracket the measured number.
By their numbers in this assay, from the lowest: compounds 1, 4, 3 and 2 (each within the scatter of the next, the first and the last beyond it).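

Within the data shown here, the first pair that isolates methyl in place of hydrogen on this amide-type nitrogen gives a step that stays within the scatter in this assay (a 1.9-fold lower number from compound 2 to compound 4 (0.28 log units; within the scatter)), so replacing the amide hydrogen here does not measurably shift the number. The two wider changes on the same carbonyl carbon are also within the scatter (a 1.5-fold lower number from compound 3 to compound 4 (0.16 log units; within the scatter); a 1.2-fold higher number from compound 1 to compound 4 (0.09 log units; within the scatter)), and this position therefore tolerates the methyl together with a changed amide end in this assay. No measurement shown offers an explanation for these small steps.

Among these compounds, the methyl is seen only with the cyclohexyl amide, so its step with a tert-butyl or benzyl end remains unknown. Also open, on these data alone, is whether a carboxylic acid or an amine at the end of the tail, or a longer chain, would move the number beyond the scatter.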